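Replacing the acid of compound 1 with a cyclopropylsulfonamide chain

This account rests on a few compounds, and the source may have more. Where it says the series, first, only, none or still open, it means among the compounds named here.

Compound 1, `CCOc1ccccc1-c1ccc(-c2nc3cnccc3c(NC(C)C(=O)O)c2C#N)cc1`, gives 2.1 in a physicochemical assay for lipophilicity, read by HPLC, at pH 7.5; on this read-out lower numbers stand for lower lipophilicity and higher numbers for higher lipophilicity.
Compound 2, `CC[C@@H](Nc1c(C#N)c(-c2ccc(-c3ccncc3C)cc2)nc2cnccc12)C(N)=O`, gives 2 in this assay.
Compound 3, `CC[C@@H](Nc1c(C#N)c(-c2ccc(Br)cc2)nc2cnccc12)C(N)=O`, gives 2.2 in this assay.

Among the three numbers compound 1 stands second highest; its nearest neighbour is compound 2, and the two differ only within the scatter, as do compound 1 and compound 3. Within the data shown here, the single step between measured compounds, a number 0.20 log units higher from compound 2 to compound 3 (within the scatter), concerns a change on an aromatic carbon and does not touch the part altered here. Compound 4, `CCOc1ccccc1-c1ccc(-c2nc3cnccc3c(NC(CC)CNS(=O)(=O)C3CC3)c2C#N)cc1`, differs from compound 1 as follows: a group of 11 heavy atoms (7 carbon, 1 nitrogen, 2 oxygen, 1 sulfur; one three-membered non-aromatic ring of carbon only) in place of a group of 5 heavy atoms (3 carbon, 2 oxygen; no ring), on a nitrogen on an aromatic ring. Among the measured compounds shown here, no measured step covers this kind of change, so its size cannot be taken from the data. Compound 4 is nonetheless expected to show a rise, a number 1.50 log units higher from compound 1 to compound 4 (beyond the scatter), and its value is estimated at 3.6, between 2.8 and 4.4.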

Compound 4, distribution coefficient: 3.6
The estimate for compound 4 equals the measured number at the digits printed; measured number inside the range.
By their numbers in this assay, from the lowest: compounds 2, 1 and 3 (each within the scatter of the next); then compound 4.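

At the nitrogen on an aromatic ring, replacing 1-carboxyethyl with the cyclopropylsulfonamide chain gives a step beyond the scatter in this assay, with a number 1.50 log units higher from compound 1 to compound 4 (beyond the scatter). Among these compounds, the one earlier step lay within the scatter and did not touch this position, so only now does this position show that a change here can carry a large difference. Nothing measured here accounts for the size of this step.

The compounds shown leave open which part of the entering chain carries the step. A chain ending in an amine, or a sulfonamide with methyl in place of cyclopropyl, would separate those parts.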